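The compounds below may be only part of what the source reports. "The series", "measured", "known", "first", "only" and "open" are said of these compounds alone.

Three compounds share one core and have each been tested in a functional assay on MCF7 cells (Homo sapiens) for antiproliferative activity, read by MTT assay, with a stated time of 48 h; on this read-out higher numbers stand for weaker inhibition and lower numbers for stronger inhibition. Compound 1 `CC(=O)N1N=C(c2ccc3ccccc3c2)OC1c1ccccc1Br` gives 5.49 ug/mL. Compound 2 `CC(=O)N1N=C(c2ccc3ccccc3c2)OC1c1ccccc1Cl` gives 2.36 ug/mL. Compound 3 `CC(=O)N1N=C(c2ccc3ccccc3c2)OC1c1cccc(F)c1` gives 1.98 ug/mL. Among these three numbers compound 2 stands second highest: it lies far from compound 1 but close to compound 3, and the step of a 1.2-fold lower number from compound 2 to compound 3 (0.08 log units; within the scatter) is too small to count as a real difference.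

Compound 4 `CC(=O)N1N=C(c2ccc3ccccc3c2)OC1c1ccccc1O` has not yet been measured. It differs from compound 2 in one place: hydroxy in place of chloro on an aromatic carbon.

Going by the values given here, none of the measured steps exchanges a halogen for a hydroxy, so no step bears on this change directly. The closest guides are the steps that swap one halogen for another or move it on the ring: a 2.3-fold lower number from compound 1 to compound 2 (0.37 log units; beyond the scatter) and a 2.8-fold lower number from compound 1 to compound 3 (0.44 log units; beyond the scatter), both modest, and a 1.2-fold lower number from compound 2 to compound 3 (0.08 log units; within the scatter), which is within the scatter. Changes of this kind on the pendant ring have so far shifted the number only modestly in either direction. With no hydroxy among the measured compounds, the direction is uncertain, and the step of a 1.3-fold higher number from compound 2 to compound 4 (0.10 log units; within the scatter) is expected to stay small. Compound 4 is therefore estimated at 3 ug/mL, with a range from 1.2 ug/mL to 8 ug/mL.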

Compound 4, half-maximal inhibitory concentration: 2.12 ug/mL
Estimate against measurement, compound 4: 1.4-fold (0.15 log units) above, and the stated range covers the measured number.
By their numbers in this assay, from the lowest: compounds 3, 4 and 2 (each within the scatter of the next); then compound 1.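

Within this assay the swap of chloro for hydroxy, on an aromatic carbon ortho to a large group, reads as a 1.1-fold lower number from compound 2 to compound 4 (0.05 log units; within the scatter), so this position tolerates a group counted as a hydrogen-bond donor and acceptor in place of one counted as neither, with no measurable difference in the number. The comparison with the fluorinated compound reads as a 1.1-fold higher number from compound 3 to compound 4 (0.03 log units; within the scatter), so compounds 2, 3 and 4 cannot be told apart, and the hydroxy compound simply joins that group. Bromo alone stands out, as a 2.6-fold lower number from compound 1 to compound 4 (0.41 log units; beyond the scatter) shows: with this third step beyond the scatter, compound 1 is the weakest of the four, and at this position the two halogens and the hydroxy do not fall into one smooth trend.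

Nothing available explains why the number stays flat across chloro and hydroxy yet shifts with bromo. From the compounds shown here alone, it remains open whether an amine, a methoxy or a carboxylic acid at this same position would stay with compounds 2, 3 and 4 or shift the number as bromo does.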